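A few compounds are considered here, and "the series" means these few. Any claim that something is new, unique, unknown or untested is made for them only; others in the source may bear on it.

Compound 1 `Fc1ccc(-c2cc(OC[C@@H]3CCCN3)cnc2Cl)cn1` gives 0.0179 nM in an assay on membranes from brain with Neuronal acetylcholine receptor; alpha4/beta2 (Rattus norvegicus) as the target; a higher number here means a weaker inhibitor, a lower number a stronger inhibitor. Compound 2 `Clc1ncc(OC[C@@H]2CCCN2)cc1-c1ccc(Br)nc1` gives 0.0195 nM in this assay. Compound 3 `Fc1cc(/C=C/c2cc(OC[C@@H]3CCN3)cnc2Cl)ccn1` gives 0.0031 nM in this assay.

Compound 1 and compound 2 share one core and differ in a single place: bromo in place of fluoro on an aromatic carbon. That change made a 1.1-fold higher number from compound 1 to compound 2 (0.04 log units; within the scatter), so the two values cannot be told apart. Compound 3 is built on a different core; the difference between the two cores is not broken down here. Its value is the lowest of the three, with compound 1 the nearest and compound 2 the furthest from it, both beyond the scatter.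

Compound 4 `Clc1ncc(OC[C@@H]2CCN2)cc1/C=C/c1ccnc(Br)c1` has not yet been measured in this assay. It stands to compound 3 as compound 2 stands to compound 1: bromo in place of fluoro on an aromatic carbon. The surroundings are not identical, since in the first pair the place is described as para to a large group and in the second pair as meta to a large group, so this is the same kind of change rather than the same change. Among the compounds shown, this change occurs twice in all, once measured.

Going by the values given here, the only measured example, compound 1 to compound 2, stayed within the scatter, and on that basis compound 4 is expected to sit close to compound 3, with the step of a 1.1-fold higher number from compound 3 to compound 4 (0.04 log units; within the scatter). The estimated value for compound 4 is 0.0034 nM, expected to fall between 0.0015 nM and 0.008 nM.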

Compound 4, inhibition constant: 0.0052 nM
Estimate against measurement, compound 4: 1.5-fold (0.18 log units) below; low and high end bracket the measured number.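

In this assay, bromo in place of fluoro, which turns the 2-fluoropyridin-4-yl group into the 2-bromopyridin-4-yl group, gave a 1.7-fold higher number from compound 3 to compound 4 (0.22 log units; within the scatter), so these two values cannot be told apart. Set beside the earlier step, the change reads the same on both cores: the same change on two cores in this assay, a 1.1-fold higher number (0.04 log units; within the scatter) from compound 1 to compound 2 and a 1.7-fold higher number (0.22 log units; within the scatter) from compound 3 to compound 4, 1.5-fold (0.19 log units) apart, within the scatter of two such steps This shows that, in these two pairs, the swap of fluoro for bromo carried from one core to the other without a detectable shift, but it rests on two steps only, says nothing of other cores or other places on the ring, and gives no ranking of the two halogens.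

The compounds shown hold only fluoro or bromo at this place, which leaves open how chloro, methyl, methoxy, a nitrile or an amine there would read in this assay. They also leave open which part of the difference between the two cores goes with the lower numbers of compound 3 and compound 4, since no pair shown separates the parts of that difference.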